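This account rests on a few compounds, and the source may have more. Where it says the series, first, only, none or still open, it means among the compounds named here.

The study asks one question of each compound: how much of it cultured cells will tolerate. This is measured in an ADME assay on Vero cells (Chlorocebus sabaeus) for cytotoxicity; a lower number here means that less compound is tolerated, a higher number that more compound is tolerated. The starting point is compound 1, `CCN(CC)CC(=O)Nc1ccc(-c2nc3cc(C(F)(F)F)ccc3n2C)cc1`, and in this assay compound 1 gives 90000 nM. Among the compounds with values here, that is the only firm number in the set; the two other values are limits rather than numbers. Compound 2, `O=[N+]([O-])c1ccc(-c2nc3cc(Cl)c(Cl)cc3[nH]2)cc1`, reaches only a limit in this assay, namely >= 100000 nM. Compound 3, `COc1cc(OC)cc(-c2nc3cc(C(F)(F)F)ccc3[nH]2)c1`, likewise stops at a limit in this assay, > 100000 nM. So compound 1 sits just under the limit of > 100000 nM in this assay, at which 1 of the 3 values shown sits, and just under (the limit of >= 100000 nM in this assay, at which 1 of the 3 values shown sits), with the other two compounds resting at those limits.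

The next compound is compound 4, `Cn1c(-c2ccc(N)cc2)nc2cc(C(F)(F)F)ccc21`. It differs from compound 1 in one place: hydrogen in place of ((diethylamino)methyl)carbonyl on a nitrogen on an aromatic ring. Within the data shown here, no measured pair in this set shows what such a change does to tolerated concentration, so there is no direct guide. Given that compound 1 already lies close to the top of the range the assay reports, the step of a 1.1-fold lower number from compound 1 to compound 4 (0.05 log units; within the scatter) is expected to be small, within the usual scatter, with no clear direction. Compound 4 is therefore estimated at 80000 nM, between 30000 nM and 100000 nM.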

Compound 4, half-maximal cytotoxic concentration: > 100000 nM
Compound 4 gave a limit, no number; the forecaster's own chance of this, stated with the estimate: 40%; at least 1.2-fold (0.09 log units) between middle value and limit.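

Within the data shown here, the step from the ((diethylamino)methyl)carbonyl group to hydrogen on a nitrogen on an aromatic ring is the first change in this set that can be read in one place, and in this assay it gives an at least 1.1-fold higher number from compound 1 to compound 4 (0.04 log units; that floor lies within the scatter). Compound 4 gives a limit rather than a number, and it joins the compounds already resting at the top of the reported range: the limit of > 100000 nM in this assay, at which 2 of the 4 values shown sit. The (((diethylamino)methyl)carbonyl)amino to amino change therefore removes all 8 heavy atoms of that group without any loss in tolerated concentration showing, so on this evidence the group is not what lets cells tolerate compound 1 at this level.

Going by these compounds, since only a floor is known for the step, it remains open how far compound 4 lies past the limit, and so whether the true difference from compound 1 goes beyond the usual scatter. On these data alone, it also remains open whether a small acetyl group, a longer chain or a carboxylic acid on the same nitrogen would leave the tolerated concentration at the limit or bring it down to a measurable number.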